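Catechol Benzyl Group Replaces Methylphenyl on Nucleoside Core

The compounds below may be only part of what the source reports. "The series", "measured", "known", "first", "only" and "open" are said of these compounds alone.

Measured compounds:
compound 1 `Cc1cccc(CNc2ncnc3c2ncn3[C@@H]2O[C@H](CO)[C@@H](O)[C@H]2O)c1` – > 166000 nM
compound 2 `COc1ccc(CNc2ncnc3c2ncn3[C@@H]2O[C@H](CO)[C@@H](O)[C@H]2O)c(OC)c1` – "not determined" (no result reported)
compound 3 `OC[C@H]1O[C@@H](n2cnc3c(NCc4ccc(F)cc4Cl)ncnc32)[C@H](O)[C@@H]1O` – > 166000 nM

In a functional assay on G-361 cells (Homo sapiens) for antiproliferative activity, with a stated time of 72 h (a lower number here means a stronger inhibitor, a higher number a weaker inhibitor), compound 1 gives > 166000 nM, which is a limit of the assay and not a number. Compound 3 gives > 166000 nM, also a limit. For compound 2 no result was reported. Within the data shown here, the one change between measured compounds, a step that the two limits leave unreadable from compound 1 to compound 3, is therefore unreadable, as both ends sit at the limit of > 166000 nM in this assay, at which 2 of the 3 values shown sit. Compound 4 `OC[C@H]1O[C@@H](n2cnc3c(NCc4cccc(O)c4O)ncnc32)[C@H](O)[C@@H]1O` differs from compound 1 by 2,3-dihydroxyphenyl in place of 3-methylphenyl on a saturated chain carbon bound to a nitrogen on an aromatic ring. Among the measured compounds shown here, no measured step bears on this change, so no direction beyond the scatter can be read; given that compound 1 sits at the limit of > 166000 nM in this assay, at which 2 of the 3 values shown sit, compound 4 is estimated at 200000 nM (50000 nM to 600000 nM), with an expected step that the limit leaves unreadable from compound 1 to compound 4, and most likely again only a limit.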

Compound 4, half-maximal inhibitory concentration: 16900 nM
For compound 4 the middle estimate is 12-fold (1.07 log units) above the measured one; the measured number lies below the stated range.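

In this assay, the exchange of the aryl group gives an at least 9.8-fold lower number from compound 1 to compound 4 (0.99 log units; beyond the scatter), and the parallel exchange gives an at least 9.8-fold lower number from compound 3 to compound 4 (0.99 log units; beyond the scatter). So the group on the saturated chain carbon bound to a nitrogen on an aromatic ring can change the read-out, which the earlier compounds could not show, since no step among them could be read. Both steps start from a value that is a limit of the assay and not a number: the limit of > 166000 nM in this assay, at which 2 of the 4 values shown sit.

The compounds shown do not tell whether both hydroxyl groups of the 2,3-dihydroxyphenyl are needed. They also leave open whether a single hydroxyl group, or a methoxy group in place of each hydroxyl group, would give a similar result.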